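From furan-2-yl to 2-hydroxyphenyl at the assay limit

A few compounds are considered here, and "the series" means these few. Any claim that something is new, unique, unknown or untested is made for them only; others in the source may bear on it.

Compound 3 `O=C(N/N=C/c1ccco1)c1cccc(S(=O)(=O)N2CCOCC2)c1` gives > 100000 nM in a functional assay on MCF7 cells (Homo sapiens) for antiproliferative activity, read by MTT assay, with a stated time of 72 h (on this read-out higher numbers stand for weaker inhibition and lower numbers for stronger inhibition), which is a limit of the assay and not a number. For the measured compounds named here, it therefore stands with the other compounds tested so far, at the limit of > 100000 nM in this assay, at which 3 of the 3 values shown sit.

Compound 4 `O=C(N/N=C/c1ccccc1O)c1cccc(S(=O)(=O)N2CCOCC2)c1` differs from compound 3 on a carbon with a double bond to nitrogen, where 2-hydroxyphenyl replaces furan-2-yl: 2-hydroxyphenyl in place of furan-2-yl on a carbon with a double bond to nitrogen.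

Two further compounds bear on this change. Compound 1 `C/C(=N\NC(=O)c1cccc(S(=O)(=O)N2CCOCC2)c1)c1cccc(N)c1` gives > 100000 nM, also a limit. Compound 2 `C/C(=N\NC(=O)c1cccc(S(=O)(=O)N2CCOCC2)c1)c1ccc(O)cc1`, which carries 4-hydroxyphenyl on that carbon, gives > 100000 nM, again a limit. Going by the values given here, the one measured step, a step that the two limits leave unreadable from compound 1 to compound 2, therefore supplies no size to carry over to the new compound. With a hydroxyphenyl group already seen at the limit in compound 2, the most likely outcome is that compound 4 also remains there and is reported only as a limit.

The expected step is an at least 1.6-fold lower number from compound 3 to compound 4 (0.22 log units; that floor lies within the scatter), and any readable change is expected to be toward stronger inhibition in this assay. Compound 4 is estimated at 60000 nM, with an expected range of 10000 nM to 100000 nM.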

Compound 4, half-maximal inhibitory concentration: 29100 nM
For compound 4 the middle estimate is 2.1-fold (0.31 log units) above the measured one; the measured number falls inside the stated range.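

In this assay, for the compounds shown here, the change from furan-2-yl to 2-hydroxyphenyl on the carbon with a double bond to nitrogen gives an at least 3.4-fold lower number from compound 3 to compound 4 (0.53 log units; beyond the scatter) and so provides the first readable step at this position. The value of compound 3 is a limit of the assay and not a number, so this step marks only a floor on the size of the change. The earlier compounds showed nothing but that limit, whereas this result shows that a change at this one position can bring a compound in this series to a measurable number: the limit of > 100000 nM in this assay, at which 3 of the 4 values shown sit.

The step removes a five-membered aromatic ring with 1 hetero atom and brings in a six-membered aromatic ring of carbon only together with 1 hydrogen-bond donor, and the compounds shown do not tell which of these accounts for the change. Going by these compounds, a plain phenyl group on the same carbon, or a methoxy group in place of the hydroxyl of 2-hydroxyphenyl, would separate the ring from the hydroxyl, and the part played by the methyl group that compound 1 and compound 2 carry on that carbon also stays open.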